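Replacing one hydroxy group on compound 3

The source may report more compounds than this note shows. Statements on the series, on what has been measured and on what is new or still open speak of the compounds shown alone.

Of the compounds shown here, three sharing a core have been measured in an ADME assay on MDCK cells (Canis lupus familiaris) for cytotoxicity; a lower number here means that less compound is tolerated, a higher number that more compound is tolerated. Compound 1 (`O=[N+]([O-])C1=CNc2ncnn2C1c1c(O)cc(O)cc1O`) returned only a limit of the assay at > 1030000 nM as its result. Compound 2 (`O=[N+]([O-])C1=CNc2nc(-c3ccco3)nn2C1c1ccc(O)cc1O`) gives 119000 nM as a number. Compound 3 (`O=[N+]([O-])C1=CNc2ncnn2C1c1ccc(O)c(O)c1O`) gives 405000 nM and so holds the higher of the two actual numbers, with the gap to compound 2 lying beyond the scatter.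

Compound 4 (`O=[N+]([O-])C1=CNc2ncnn2C1c1ccc(O)cc1O`) differs from compound 3 by having hydrogen in place of hydroxy on an aromatic carbon, at a place ortho to two hydroxy groups and meta to a large group. Among the measured compounds shown here, no measured pair isolates this change, so the expectation leans on compound 3 at 405000 nM as the closest reference. The estimated step of a 1.0-fold lower number from compound 3 to compound 4 (0.01 log units; within the scatter) is expected to stay within the scatter, in neither direction. For compound 4 the expected half-maximal cytotoxic concentration is 400000 nM with an estimated range from 170000 nM to 950000 nM in this assay.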

Compound 4, half-maximal cytotoxic concentration: > 1080000 nM
Compound 4 ended at the assay's limit; the forecaster's own chance of this, stated with the estimate: 15%; middle value at least 2.7-fold (0.43 log units) away from the limit.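

In this assay, among the compounds shown here, the pair of compound 3 and compound 4 isolates the hydroxy ortho to two hydroxy groups and meta to a large group for the first time, and replacing it with hydrogen gives an at least 2.6-fold higher number from compound 3 to compound 4 (0.42 log units; beyond the scatter), so more compound is tolerated without this hydroxy. Hydrogen in place of furan-2-yl on an aromatic carbon gives an at least 9.0-fold higher number from compound 2 to compound 4 (0.95 log units; beyond the scatter), which is a larger step in the same direction. Compound 4 returned only a limit of the assay, so both steps give minimum sizes: the limit of > 1080000 nM in this assay, at which 1 of the 4 values shown sits.

As far as these compounds go, the step between compound 1 and compound 4 cannot be read, as compound 1 also stands at a limit: the limit of > 1030000 nM in this assay, at which 1 of the 4 values shown sits. Also open is whether an amine or a carboxylic acid in place of this hydroxy would match hydrogen or the hydroxy of compound 3.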